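Working notes: fluoro to chloro, compound 3 to compound 4

This account rests on a few compounds, and the source may have more. Where it says the series, first, only, none or still open, it means among the compounds named here.

Compound 1 `O=C1CCc2ccc(OCc3cccc(Br)c3)cc2N1`: 49200 nM in an assay on isolated protein for inhibition of Amine oxidase [flavin-containing] A (Homo sapiens), read by fluorescence, with a stated time of 15 min; on this read-out lower numbers stand for stronger inhibition and higher numbers for weaker inhibition
Compound 2 `CC(=O)c1ccc(OCc2cccc(F)c2)cc1O`: > 100000 nM
Compound 3 `CC(=O)c1ccc(OCc2cccc(F)c2)cc1F`: > 100000 nM

Compound 3 gives only a limit in this assay, not a number. Compound 2 also sits at a limit, so two of the three values shown are limits (the limit of > 100000 nM in this assay, at which 2 of the 3 values shown sit). For the measured compounds named here, the one step between measured compounds, a step that the two limits leave unreadable from compound 2 to compound 3, therefore cannot be read. Going by the values given here, compound 1 gives a number, but on a different core, and no step joins it to compound 3. Compound 4 `CC(=O)c1ccc(OCc2cccc(Cl)c2)cc1F` differs from compound 3 by chloro in place of fluoro on an aromatic carbon. Among the compounds with values here, no measured step covers this exchange, so the expectation rests on compound 3 alone: compound 4 is expected to stay near the limit, the step of a number no higher from compound 3 to compound 4 (the limit leaves the size open) expected to be within scatter. Estimate for compound 4: 100000 nM, range 30000 nM to 300000 nM.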

Compound 4, half-maximal inhibitory concentration: > 100000 nM
Compound 4 gave a limit, no number; the forecaster's own chance of this, stated with the estimate: 60%; the middle value sits exactly at the limit.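

Compound 3 and compound 4 both give only limits, so no step between them can be read: the limit of > 100000 nM in this assay, at which 3 of the 4 values shown sit.

The compounds shown leave open how chloro and fluoro compare on the shared core in this assay.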